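Swapping One Aromatic Group on a Shared Core

The compounds below may be only part of what the source reports. "The series", "measured", "known", "first", "only" and "open" are said of these compounds alone.

In an ADME assay on the whole organism (Mus musculus, strain CD-1) for pharmacokinetics, at a dose of 10 mg/kg by the oral route (a lower number here means that a smaller share of the oral dose reaches the circulation, a higher number that a larger share of the oral dose reaches the circulation), compound 1 `CCCOc1cc([C@](O)(CCN(C)C)[C@@H](c2cc3cc(Br)ccc3nc2OC)c2ccnc(OC)c2OC)cc(OC)n1` gives 50%. Compound 3 `CCOc1cc([C@](O)(CCN(C)C)[C@@H](c2cc3cc(Br)ccc3nc2OC)c2ccnc(OC)c2OC)cc(OC(C)C)n1` gives 58%, which lies within the scatter of compound 1. Compound 2 `COc1cc([C@](O)(CCN(C)C)[C@@H](c2cc3cc(Br)ccc3nc2OC)c2cccc(OC)c2F)cc(OC(F)F)n1` gives 83%, higher than compound 1 and beyond the scatter. Compound 1 therefore stands level with compound 3 and well under compound 2.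

Compound 4 `COc1nc2ccc(Br)cc2cc1[C@@H](c1ccnc(OC)c1OC)[C@@](O)(CCN(C)C)c1cc(SC)nc(SC)c1` keeps the rest of compound 1 and differs in one group: a group of 10 heavy atoms (7 carbon, 1 nitrogen, 2 sulfur; one six-membered aromatic ring with 1 hetero atom) in place of a group of 12 heavy atoms (9 carbon, 1 nitrogen, 2 oxygen; one six-membered aromatic ring with 1 hetero atom), on a saturated chain carbon bound to an oxygen on a saturated carbon and two saturated chain carbons. Going by the values given here, none of the three measured compounds carries sulfur, and no measured pair differs in one place alone, so the data offer no direct guide to this change. The expectation therefore stays close to compound 1 at 50%, with a wide margin on either side. The estimated step of a number 3 percentage points lower from compound 1 to compound 4 (within the scatter) is expected to stay within the scatter, with no firm direction. In this assay, the estimate for compound 4 is 47%, with an expected range from 25% to 72%.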

Compound 4, oral bioavailability: 41%
Compound 4: middle estimate off by 6 percentage points, on the high side; measured number inside the range.
By their numbers in this assay, from the lowest: compounds 4, 1 and 3 (each within the scatter of the next, the first and the last beyond it); then compound 2.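

Going by these compounds alone, the pair of compound 1 and compound 4 gives the first comparison in this set that differs in one place alone, and the first look at a group with 2 sulfur atoms at this place on the saturated chain carbon. In this assay, exchanging the group of 12 heavy atoms for the group of 10 heavy atoms gives a number 9 percentage points lower from compound 1 to compound 4 (within the scatter), so the two compounds stand level and the sulfur-containing group can take this place without a change beyond the scatter. Nothing measured here explains this result.

On these data alone, it remains open whether other groups at this place would also stand level, such as a six-membered aromatic ring carrying an amine, a carboxylic acid or a longer chain. Compound 2, at 83%, differs from compound 1 in more than one place, so the shown compounds do not tell which of its groups goes with that value.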